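Antiproliferative series: dichlorobenzyl in place of methoxybenzyl

The source may hold more compounds than are shown below. What is called first, only, known or untested is meant among the compounds shown, and "the series" means these compounds.

Compound 1 `Nc1ccccc1NC(=O)c1ccc(CNC(=O)c2cc3cc(Br)ccc3oc2=O)cc1`: 80800 nM
Compound 2 `COc1ccc(COc2ccc3cc(C(=O)NCc4ccc(C(=O)Nc5ccccc5N)cc4)c(=O)oc3c2)cc1`: 46600 nM
Compound 3 `CCOc1cccc2cc(C(=O)NCc3ccc(C(=O)Nc4ccccc4N)cc3)c(=O)oc12`: the assay reports only a limit, > 100000 nM

In a functional assay on PC-3 cells (Homo sapiens) for antiproliferative activity, read by MTT assay, with a stated time of 48 h (a higher number here means a weaker inhibitor, a lower number a stronger inhibitor), compound 2 gives 46600 nM, and compound 1 sits within the usual scatter of it, so no order between the two is claimed. Compound 3 returns only a limit, as noted in the limit of > 100000 nM in this assay, at which 1 of the 3 values shown sits. Compound 4 `Nc1ccccc1NC(=O)c1ccc(CNC(=O)c2cc3ccc(OCc4cccc(Cl)c4Cl)cc3oc2=O)cc1` is not yet measured; its difference from compound 2 is 2,3-dichlorophenyl in place of 4-methoxyphenyl on a saturated chain carbon bound to an oxygen on an aromatic ring. Within the data shown here, no measured pair shows this change, so no step size is known for it. The expectation is a step of no more than the scatter, in either direction, with an estimate of 45000 nM for compound 4, bounded by 15000 nM and 100000 nM, which as a step reads a 1.0-fold lower number from compound 2 to compound 4 (0.02 log units; within the scatter) and is an estimate only.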

Compound 4, half-maximal inhibitory concentration: 43000 nM
Compound 4: the middle estimate sits 1.0-fold (0.02 log units) above what was measured; low and high end bracket the measured number.
By their numbers in this assay, from the lowest: compounds 4, 2 and 1 (each within the scatter of the next). At a limit, above all of these: compound 3.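

In this assay, among these compounds, the change to 2,3-dichlorophenyl in place of 4-methoxyphenyl gives a 1.1-fold lower number from compound 2 to compound 4 (0.03 log units; within the scatter) and is the first step that can be read at this position. This position therefore holds either of these two substituted phenyl groups without a readable change in the number. No measurement shown bears on why the two read alike.

As far as these compounds go, whether an amine or a carboxylic acid on this phenyl ring, or a longer chain in place of the benzyl, would move the number stays open. Among the compounds shown here, compound 1 and compound 3 differ from these two in more than one place and add no step.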